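The source may report more compounds than this note shows. Statements on the series, on what has been measured and on what is new or still open speak of the compounds shown alone.

Of the compounds shown here, two carry numbers so far. Compound 1 `CCOC(=O)[C@@H]1CC(=O)c2sccc2[C@H]1c1ccc(OC)cc1` gives 26.2% in a physicochemical assay, read by spectrophotometry, with a stated time of 20 min, tested at 100 ug/mL; on this read-out lower numbers stand for a weaker effect and higher numbers for a stronger effect at the one concentration tested. Compound 2 `CCOC(=O)[C@@H]1CC(=O)c2sccc2[C@H]1c1ccccc1OC` gives 21.7% in this assay, the lower of the two numbers, though its gap to compound 1 lies within the usual scatter. Compound 3 `CCOC(=O)[C@@H]1CC(=O)c2sccc2[C@H]1c1ccc(OC)cc1OC` is not yet measured; relative to compound 2 it carries methoxy in place of hydrogen on an aromatic carbon. Going by the values given here, no step between measured compounds is available to size this change, so the expected step of a number 3.3 percentage points higher from compound 2 to compound 3 (within the scatter) in this assay is small, with no direction beyond the scatter. Compound 3 is therefore estimated at 25%, within 12% to 38%.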

Compound 3, a percentage reported as activity, at one concentration (the size of the read-out at that concentration, not a potency): 20.8%
For compound 3 the middle estimate is 4.2 percentage points above the measured one; the range from low to high includes it.
By their numbers in this assay, from the lowest: compounds 3, 2 and 1 (each within the scatter of the next).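

In this assay, methoxy in place of hydrogen on an aromatic carbon, meta to a methoxy group and para to a large group, gives a number 0.9 percentage points lower from compound 2 to compound 3 (within the scatter), and the same kind of change gives a number 5.4 percentage points lower from compound 1 to compound 3 (within the scatter). Adding this second methoxy group therefore produces no readable change from either compound with a single methoxy group. Nothing at hand bears on the reason for this result.

Still open, going by these compounds, is whether any other group at this position would give a step beyond the scatter, such as an amine, a carboxylic acid or chlorine. Replacing the ethyl ester of the shared core with a carboxylic acid is also untested by these compounds.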